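This account rests on a few compounds, and the source may have more. Where it says the series, first, only, none or still open, it means among the compounds named here.

In a functional assay on MCF7 cells (Homo sapiens) for antiproliferative activity, read by MTT assay, with a stated time of 48 h (a lower number here means a stronger inhibitor, a higher number a weaker inhibitor), compound 1 `C=C1[C@H](OCC(C)C)[C@@H](OC(C)=O)[C@@H](OC(C)=O)C(C)(C)/C=C/[C@H](C)[C@H](OC(=O)c2ccccc2)[C@@]2(O)C[C@@](C)(OC(C)=O)[C@H](OC(C)=O)[C@@H]2[C@H]1OCC(C)C` gives > 100000 nM, a limit and not a number. Compound 2 `CC(=O)O[C@@H]1[C@@H]2[C@@H](OCC(C)C)C3(CO3)[C@H](O)[C@@H](O)[C@@H](O)C(C)(C)/C=C/[C@H](C)[C@H](OC(=O)c3ccccc3)[C@@]2(O)C[C@@]1(C)O` gives > 100000 nM, which is also a limit. Among the measured compounds shown here, no measured step is therefore available. Compound 3 `C=C1[C@H](OC(C)=O)[C@@H](OC(C)=O)[C@@H](OC(C)=O)C(C)(C)/C=C/[C@H](C)[C@H](OC(=O)c2ccccc2)[C@@]2(O)C[C@@](C)(OC(C)=O)[C@H](OC(C)=O)[C@@H]2[C@H]1OCC(C)C` has acetyl in place of isobutyl on an oxygen on a saturated carbon. With compound 1 sitting at the limit of > 100000 nM in this assay, at which 2 of the 2 values shown sit, little change is expected in this assay, and none beyond the scatter in either direction can be foreseen. The estimated step of an at least 1.1-fold lower number from compound 1 to compound 3 (0.04 log units; that floor lies within the scatter) is expected to remain small. Compound 3 is estimated at 90000 nM, with an expected range of 30000 nM to 200000 nM.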

Compound 3, half-maximal inhibitory concentration: 74300 nM
Compound 3: middle estimate off by 1.2-fold (0.08 log units), on the high side; low and high end bracket the measured number.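

With acetyl in place of isobutyl on an oxygen on a saturated carbon, compound 3 is the only compound shown that gives a number rather than a limit in this assay. The change reads as an at least 1.3-fold lower number from compound 1 to compound 3 (0.12 log units; that floor lies within the scatter), so the data show no gain beyond the scatter. Its full size cannot be read because compound 1 sits at a limit: the limit of > 100000 nM in this assay, at which 2 of the 3 values shown sit.

As far as these compounds go, whether a longer chain or an amine on this oxygen would give a number well clear of that limit remains open. So does whether other acyl groups here would behave like acetyl.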